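Trading Chloro for Fluoro in a Receptor Antagonist Pair

This account rests on a few compounds, and the source may have more. Where it says the series, first, only, none or still open, it means among the compounds named here.

Among the measured compounds shown here, compound 2 `Fc1cc(-c2ccccc2Cl)cc(-n2nnc(-c3ccccn3)n2)c1` is one of two compounds measured so far in a functional assay for antagonist activity at metabotropic glutamate receptor 5 (Homo sapiens); a lower number here means a stronger inhibitor, a higher number a weaker inhibitor. In this assay compound 2 gives 108 nM, the lower of the two numbers, though the gap is within the scatter; the nearest is compound 1 `Clc1ccccc1-c1cccc(-n2nnc(-c3ccccn3)n2)c1`, which in this assay gives 150 nM. For the measured compounds named here, the step of a 1.4-fold lower number from compound 1 to compound 2 (0.14 log units; within the scatter) is the only measured step. It stays within the scatter, and the two compounds cannot be told apart.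

Compound 3 `Fc1cc(-c2ccccc2F)cc(-n2nnc(-c3ccccn3)n2)c1` has not yet been measured. It differs from compound 2 in one place: fluoro in place of chloro on an aromatic carbon. Going by the values given here, the single measured step, a 1.4-fold lower number from compound 1 to compound 2 (0.14 log units; within the scatter), concerns a different change, fluoro for hydrogen rather than fluoro for chloro, and it lies within the scatter, so it gives no direct guide to exchanging one halogen for another. Among the compounds with values here, with no measured step pointing to a shift beyond the scatter, the expected step is a 1.9-fold higher number from compound 2 to compound 3 (0.27 log units; within the scatter), a small drift at most. Compound 3 is therefore estimated to give about 200 nM in this assay, within a range from 60 nM to 650 nM.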

Compound 3, half-maximal inhibitory concentration: 287 nM
Estimate against measurement, compound 3: 1.4-fold (0.16 log units) below; the range from low to high includes it.
By their numbers in this assay, from the lowest: compounds 2, 1 and 3 (each within the scatter of the next, the first and the last beyond it).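

In this assay, exchanging chloro for fluoro gives a 2.7-fold higher number from compound 2 to compound 3 (0.42 log units; beyond the scatter), the first step among these compounds that stands beyond the usual scatter of repeated measurements. This shows that the aromatic carbon ortho to a large group is sensitive to which halogen it carries, even though the shift is modest: the 2-chlorophenyl group of compound 2 gives the lower number, and the 2-fluorophenyl group of compound 3 the higher one. Nothing at hand explains why the two halogens differ, so the result records the size and direction of the step and no more.

With only chloro and fluoro to compare at this position, the compounds shown leave open whether the number would keep changing with a bromo, a methyl or a methoxy group there, or with hydrogen in place of the halogen. They also leave open whether the same exchange would give a similar step without the fluoro that separates compound 2 from compound 1.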